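Swapping the Amine on a Corticotropin-Releasing Factor Antagonist

The compounds below may be only part of what the source reports. "The series", "measured", "known", "first", "only" and "open" are said of these compounds alone.

Compound 1 `Cc1cc(C)c(N2CCCn3c2nc(C)c3C(=O)N(CC2CC2)CC2CC2)c(C)c1`: 3400 nM
Compound 2 `CCCN(Cc1c(C(F)(F)F)nc2n1CCCN2c1c(C)cc(C)cc1C)CC1CCC1`: 21 nM

In an in vitro assay on IMR-32 cells for displacement of a labelled ligand from corticotropin-releasing factor receptor 1 (Homo sapiens) (on this read-out higher numbers stand for weaker inhibition and lower numbers for stronger inhibition), compound 2 gives 21 nM, the lowest of the two numbers; in this assay compound 1 gives 3400 nM, a gap well beyond the usual scatter. Compound 3 `Cc1cc(C)c(N2CCCn3c2nc(C(F)(F)F)c3CN2CC=CCC2)c(C)c1` differs from compound 2 by a group of 6 heavy atoms (5 carbon, 1 nitrogen; one six-membered non-aromatic ring with 1 hetero atom) in place of a group of 9 heavy atoms (8 carbon, 1 nitrogen; one four-membered non-aromatic ring of carbon only), on a saturated chain carbon bound to an aromatic carbon. For the measured compounds named here, with only two measured compounds, and neither pair differing in one place, the effect of this change in this assay is unknown. A moderate weakening is expected, a 4.8-fold higher number from compound 2 to compound 3 (0.68 log units; beyond the scatter), since the group that enters is smaller than the one that leaves. Compound 3 is estimated at 100 nM, between 25 nM and 500 nM.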

Compound 3, inhibition constant: 364 nM
Estimate against measurement, compound 3: 3.6-fold (0.56 log units) below; the measured number falls inside the stated range.
By their numbers in this assay, from the lowest: compound 2; then compound 3; then compound 1.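

On a saturated chain carbon bound to an aromatic carbon, exchanging (cyclobutylmethyl)(propyl)amino for the smaller six-membered ring with its double bond gives a 17-fold higher number from compound 2 to compound 3 (1.24 log units; beyond the scatter) in this assay. The value at this position therefore depends strongly on which amine it carries. Nothing measured here says why the step is so large.

Still open, going by these compounds, is which part of the change counts: losing the propyl chain, losing the cyclobutyl ring, or bringing in the double bond. A piperidine or a dipropylamino group on that carbon would help separate these.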